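The compounds below may be only part of what the source reports. "The series", "measured", "known", "first", "only" and "open" are said of these compounds alone.

Compound 1, `Cc1nc(N2CCCCC2)c2nnn(-c3ccc(C(C)C)cc3Br)c2n1`: 46 nM
Compound 2, `CCCC(CC)Nc1nc(C)nc2c1ncn2-c1ccc(C(C)C)cc1Br`: 4.4 nM

Both numbers come from an in vitro assay on 293-EBNA cells for binding affinity to corticotropin-releasing factor receptor 1 (Homo sapiens); on this read-out lower numbers stand for stronger inhibition and higher numbers for weaker inhibition. Of the two, compound 1 has the higher number and therefore the weaker binding; compound 2 stands well below it, a gap beyond the usual scatter. Compound 3, `CCOCC(COCC)Oc1nc(C)nc2c1nnn2-c1ccc(C(C)C)cc1Br`, is not yet measured. It differs from compound 1 in one place: a group of 10 heavy atoms (7 carbon, 3 oxygen; no ring) in place of a group of 6 heavy atoms (5 carbon, 1 nitrogen; one six-membered non-aromatic ring with 1 hetero atom), on an aromatic carbon. Going by the values given here, no measured pair shows this exact change, so the size of the step is uncertain. A moderate step toward a lower number is expected, a 3.1-fold lower number from compound 1 to compound 3 (0.49 log units; beyond the scatter). For compound 3 the expected value in this assay is 15 nM, within a range from 3 nM to 80 nM.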

Compound 3, inhibition constant: 39.7 nM
Compound 3: middle estimate off by 2.6-fold (0.42 log units), on the low side; the range from low to high includes it.
By their numbers in this assay, from the lowest: compound 2; then compounds 3 and 1 (each within the scatter of the next).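

In this assay, putting a group of 10 heavy atoms (7 carbon, 3 oxygen; no ring) in place of piperidin-1-yl on this aromatic carbon gives a 1.2-fold lower number from compound 1 to compound 3 (0.06 log units; within the scatter). At this position, then, two groups that differ in size, ring and hydrogen-bond acceptor count are not told apart by this read-out. Nothing available explains this result. From the compounds shown here alone, it remains open whether a much smaller group here, such as methoxy or dimethylamino, would also leave the number unchanged. The same question stands for a morpholine ring.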